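A Dichlorophenyl Sulfonamide Tested Against HSP60/HSP10

The source may report more compounds than this note shows. Statements on the series, on what has been measured and on what is new or still open speak of the compounds shown alone.

compound 1 `CCc1ccc(S(=O)(=O)Nc2ccc(-c3nc4ccccc4o3)cc2)cc1` — > 100000 nM
compound 2 `O=S(=O)(Nc1ccc(-c2nc3cc(NS(=O)(=O)c4ccccc4)ccc3o2)cc1)c1ccccc1` — 80000 nM
compound 3 `COc1ccc(Cl)cc1S(=O)(=O)Nc1ccc2oc(-c3ccccc3)nc2c1` — > 100000 nM

In an assay on cells for inhibition of HSP60/HSP10 (Homo sapiens), with a stated time of 60 min (a higher number here means a weaker inhibitor, a lower number a stronger inhibitor), compound 1 reaches only a limit of the assay, > 100000 nM, and gives no number. Compound 3 likewise sits at a limit in this assay, > 100000 nM. Compound 2 gives 80000 nM in this assay. Compound 1 thus stands at the weak end of what is shown, where the limit of > 100000 nM in this assay, at which 2 of the 3 values shown sit, records two of the three compounds.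

The untested compound 4 `O=S(=O)(Nc1ccc(-c2nc3ccccc3o2)cc1)c1ccc(Cl)c(Cl)c1` differs from compound 1 in one place: 3,4-dichlorophenyl in place of 4-ethylphenyl on a sulfonyl sulfur. For the measured compounds named here, no measured pair of the same kind is available to guide the size of the change, so the expected step of a number no higher from compound 1 to compound 4 (the limit leaves the size open) in this assay is none beyond the usual scatter. Compound 4 is therefore estimated at 100000 nM, within a range from 30000 nM to 300000 nM, and is expected most likely to return only a limit again.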

Compound 4, half-maximal inhibitory concentration: 25000 nM
For compound 4 the middle estimate is 4.0-fold (0.60 log units) above the measured one, and the stated range ends above it.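

In this assay, 3,4-dichlorophenyl in place of 4-ethylphenyl on a sulfonyl sulfur gives an at least 4.0-fold lower number from compound 1 to compound 4 (0.60 log units; beyond the scatter), showing that this position responds to the group it carries, even though both groups have the same number of heavy atoms. The size of the step remains a minimum, not a measured difference, because compound 1 stands only at a limit: the limit of > 100000 nM in this assay, at which 2 of the 4 values shown sit.

Going by these compounds, whether one chlorine alone would produce the change remains open. So does how an amine, a carboxylic acid or a longer chain would behave on the sulfonyl sulfur.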